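Aryl linker in place of cyclohexyl on the oxadiazole

The source may report more compounds than this note shows. Statements on the series, on what has been measured and on what is new or still open speak of the compounds shown alone.

Measured compounds:
Compound 1 `CCCCCCCCCCc1ccc(-c2noc([C@@H]3CCCN3)n2)cc1` — 21%
Compound 2 `CCCCCCCCCCc1ccc(-c2noc(C3CCNCC3)n2)cc1` — 66%
Compound 3 `CCCCCCCCCCc1ccc(-c2noc([C@H]3CCC[C@@H](N)C3)n2)cc1` — 29%

In an assay on HeLa cells for inhibition of sphingosine-1-phosphate transporter SPNS2 (Mus musculus), read by LC-MS, tested at 2 uM (a higher number here means more inhibition at the concentration tested (going by the name of the read-out), a lower number less inhibition), compound 3 stands second highest of the three numbers. Its nearest neighbour is compound 1: the step of a number 8 percentage points higher from compound 1 to compound 3 (within the scatter) lies within the scatter, so the two cannot be ordered. The step of a number 37 percentage points lower from compound 2 to compound 3 (beyond the scatter) is large and beyond the scatter; compound 2 is clearly the higher of that pair, as the step of a number 45 percentage points higher from compound 1 to compound 2 (beyond the scatter) also shows.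

Compound 4 `CCCCCCCCCCc1ccc(-c2noc(-c3cccc(CN)c3)n2)cc1` differs from compound 3 in one place: 3-(aminomethyl)phenyl in place of 3-aminocyclohexyl on an aromatic carbon. Among the measured compounds shown here, no measured step exchanges a saturated carbon ring for an aromatic one, so none of the three steps bears directly on this change. The measured steps show that the group on this carbon can move this assay by a large amount in either direction, or not at all. For the measured compounds named here, with no direct precedent, the step of a number 6 percentage points higher from compound 3 to compound 4 (within the scatter) is expected to stay within the scatter, with wide uncertainty. Compound 4 is therefore estimated at 35%, within a range from 10% to 65%.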

Compound 4, a percentage reported as inhibition, at one concentration (the size of the read-out at that concentration, not a potency): 2%
Estimate against measurement, compound 4: 33 percentage points above; the whole stated range lies above it.
By their numbers in this assay, from the lowest: compound 4; then compounds 1 and 3 (each within the scatter of the next); then compound 2.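

In this assay, the step of a number 27 percentage points lower from compound 3 to compound 4 (beyond the scatter) shows that 3-(aminomethyl)phenyl in place of 3-aminocyclohexyl does not leave the number where it was: among the compounds shown, this is the first exchange of a non-aromatic ring for an aromatic one, and it lowers the number beyond the scatter. The steps of a number 19 percentage points lower from compound 1 to compound 4 (beyond the scatter) and a number 64 percentage points lower from compound 2 to compound 4 (beyond the scatter) place compound 4 lowest of the four, so a group carrying an amine on this carbon is no guarantee of a high number. No measurement shown here gives a reason for this drop.

As far as these compounds go, it remains open whether the low number goes with the aromatic ring itself or with the aminomethyl arm it carries, as an aminophenyl group could show. From the compounds shown here alone, it is also open how a carboxylic acid in place of the amine would read in this assay.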